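The compounds below may be only part of what the source reports. "The series", "measured", "known", "first", "only" and "open" are said of these compounds alone.

Of the compounds shown here, three built on one shared core have been measured in a functional assay on NCI-H1299 cells (Homo sapiens) for inhibition, read by CCK-8 assay, with a stated time of 72 h, tested at 1 uM; on this read-out lower numbers stand for less inhibition of growth and higher numbers for more inhibition of growth at the one concentration tested. Compound 1 `CN(C)C(=O)c1cc2cnc(Nc3ccc(NC(=O)C4(C(=O)Nc5ccccc5)CC4)cc3)nc2n1C1CCCC1` gives 71.2%. Compound 2 `CN(C)C(=O)c1cc2cnc(Nc3ccc(NC(=O)C4(C(=O)Nc5cccc(O)c5)CC4)cc3)nc2n1C1CCCC1` gives 77.5%, and compound 3 `CN(C)C(=O)c1cc2cnc(Nc3ccc(NC(=O)C4(C(=O)Nc5ccc(F)cc5)CC4)cc3F)nc2n1C1CCCC1` gives 52.3%. Compound 2 thus carries the highest of the three numbers, yet compound 1 sits within the scatter of it, and only compound 3 lies beyond the scatter on the lower side. Going by the values given here, the one step between compounds that differ in a single place is a number 6.3 percentage points higher from compound 1 to compound 2 (within the scatter), a change too small to count as real.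

Compound 4 `CN(C)C(=O)c1cc2cnc(Nc3ccc(NC(=O)C4(C(=O)Nc5ccc(Cl)c(C(F)(F)F)c5)CC4)cc3)nc2n1C1CCCC1` differs from compound 2 by 4-chloro-3-(trifluoromethyl)phenyl in place of 3-hydroxyphenyl on an amide-type nitrogen. Among the compounds with values here, no measured step repeats this exchange: compound 3 differs from compound 2 in more than one place, so its gap cannot be read as the effect of one change. Within the data shown here, the only single-place step seen, from compound 1 to compound 2, stayed within the scatter, so no strong move in this assay can be argued for, while the spread across the three numbers leaves room in either direction. Compound 4 is therefore expected to show 65%, within a range from 45% to 85%, an estimated step of a number 12.5 percentage points lower from compound 2 to compound 4 (beyond the scatter).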

Compound 4, percent growth inhibition at one concentration: 39.5%
Estimate against measurement, compound 4: 25.5 percentage points above, and the stated range ends above it.
By their numbers in this assay, from the lowest: compound 4; then compound 3; then compounds 1 and 2 (each within the scatter of the next).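

In this assay this position on the amide-type nitrogen proves able to move the read-out strongly: 4-chloro-3-(trifluoromethyl)phenyl gives a number 38 percentage points lower from compound 2 to compound 4 (beyond the scatter), and measured against the plain phenyl it gives a number 31.7 percentage points lower from compound 1 to compound 4 (beyond the scatter). The earlier single-place change at this ring, a hydroxy in place of a hydrogen, stayed within the scatter, so the ring attached to this nitrogen can tolerate one change and still lose much of its growth inhibition with another. Nothing at hand explains why this exchange lowers the number.

The chlorine and the trifluoromethyl enter together, so the compounds shown cannot say which of the two goes with the drop. Going by these compounds, how a phenyl carrying an amine or a carboxylic acid at this position would behave also stays open.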